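The compounds below may be only part of what the source reports. "The series", "measured", "known", "first", "only" and "open" are said of these compounds alone.

Compound 3 `O=C1O[C@H]([C@@H](O)Cn2cc(CNS(=O)(=O)c3ccc(Cl)cc3)nn2)C(OCc2ccccc2)=C1OCc1ccccc1` has the lowest number of the three compounds in an ADME assay on HFF cells (Homo sapiens) for cytotoxicity, read by MTT assay, with a stated time of 72 h (a higher number here means a weaker inhibitor, a lower number a stronger inhibitor), giving 20 nM. Compound 2 `COc1ccccc1-c1cn(C[C@H](O)[C@H]2OC(=O)C(OCc3ccccc3)=C2OCc2ccccc2)nn1` gives 50 nM in this assay, and compound 1 `O=C1O[C@H]([C@@H](O)Cn2cc(-c3cccc(O)c3)nn2)C(OCc2ccccc2)=C1OCc1ccccc1` gives 39000 nM. Compound 4 `Cc1ccc(-c2cn(C[C@H](O)[C@H]3OC(=O)C(OCc4ccccc4)=C3OCc3ccccc3)nn2)cc1` arises from compound 3 by one change: 4-methylphenyl in place of (((4-chlorophenyl)sulfonyl)amino)methyl on an aromatic carbon. Among the compounds with values here, no measured step swaps exactly these two groups. Within the data shown here, two steps bear on it: the step of a 2.5-fold lower number from compound 2 to compound 3 (0.40 log units; beyond the scatter) is modest, whereas the step of a 2000-fold lower number from compound 1 to compound 3 (3.29 log units; beyond the scatter) is large, so replacing the entering group by another aryl group has ranged from a small to a very large rise in number. A rise of modest size is expected here, a 5.0-fold higher number from compound 3 to compound 4 (0.70 log units; beyond the scatter), with wide uncertainty. Compound 4 is therefore estimated to give 100 nM, somewhere between 15 nM and 2000 nM.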

Compound 4, half-maximal inhibitory concentration: > 100000 nM
Compound 4 ended at the assay's limit; the forecaster's own chance of this, stated with the estimate: 5%; at least 1000-fold (3.00 log units) between middle value and limit.
By their numbers in this assay, from the lowest: compound 3; then compound 2; then compound 1. At a limit, above all of these: compound 4.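

Compound 4 sits at a limit of the assay, not at a measured number: the limit of > 100000 nM in this assay, at which 1 of the 4 values shown sits. With 4-methylphenyl on this aromatic carbon, the result is an at least 5000-fold higher number from compound 3 to compound 4 (3.69 log units; beyond the scatter) and an at least 2000-fold higher number from compound 2 to compound 4 (3.30 log units; beyond the scatter), and still an at least 2.5-fold higher number from compound 1 to compound 4 (0.40 log units; beyond the scatter). An aryl group here therefore does not by itself give a low number, since 2-methoxyphenyl and 4-methylphenyl lie far apart. The compounds shown leave open whether a plain phenyl or a 4-methoxyphenyl would fall with compound 2 or with compound 4. From the compounds shown here alone, how an amine on that aryl ring would behave also stays open.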